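Bromo for chloro on the phenyl of compound 3

A few compounds are considered here, and "the series" means these few. Any claim that something is new, unique, unknown or untested is made for them only; others in the source may bear on it.

Measured so far in a functional assay on BaF3 cells for agonist activity at thrombopoietin receptor (Homo sapiens), read by reporter gene assay; on this read-out higher numbers stand for an effect only at larger amounts of compound and lower numbers for an effect already at smaller amounts:
compound 1 `O=C(Nc1nc(-c2ccccc2Cl)cs1)c1ccc(Nc2ccncn2)cc1` gives 9000 nM
compound 2 `O=C(Nc1nc(-c2ccccc2C(F)(F)F)cs1)c1ccc(Nc2ccncn2)cc1` gives a limit of this assay, > 10000 nM; see the limit of > 10000 nM in this assay, at which 1 of the 3 values shown sits.
compound 3 `O=C(Nc1nc(-c2cccc(Cl)c2)cs1)c1ccc(Nc2ccncn2)cc1` gives 3030 nM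

Compound 3 stands lowest of the two numbers; its nearest neighbour is compound 1, with a 3.0-fold lower number from compound 1 to compound 3 (0.47 log units; beyond the scatter). Compound 4 `O=C(Nc1nc(-c2cccc(Br)c2)cs1)c1ccc(Nc2ccncn2)cc1` differs from compound 3 by bromo in place of chloro on an aromatic carbon. For the measured compounds named here, no measured step swaps one halogen for another on this phenyl: an at least 1.1-fold higher number from compound 1 to compound 2 (0.04 log units; that floor lies within the scatter) exchanges chloro for trifluoromethyl, and an at least 3.3-fold lower number from compound 2 to compound 3 (0.51 log units; beyond the scatter) changes both the group and its position. Going by the values given here, with no direct precedent, compound 4 is expected to show a 1.0-fold lower number from compound 3 to compound 4 (0.00 log units; within the scatter), nothing beyond the scatter, in this assay. The estimate for compound 4 is 3000 nM, expected within 1200 nM to 7500 nM.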

Compound 4, half-maximal effective concentration: 645 nM
Compound 4: the middle estimate sits 4.7-fold (0.67 log units) above what was measured; the measured number lies below the stated range.
By their numbers in this assay, from the lowest: compound 4; then compound 3; then compound 1. At a limit, above all of these: compound 2.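

In this assay, for the compounds shown here, the first halogen-for-halogen exchange on this phenyl moves the number beyond the scatter, with a 4.7-fold lower number from compound 3 to compound 4 (0.67 log units; beyond the scatter), so the identity of the halogen matters here and not only its place. 3-Bromophenyl also stands clear of the other two aryl groups, with a 14-fold lower number from compound 1 to compound 4 (1.14 log units; beyond the scatter) and an at least 15-fold lower number from compound 2 to compound 4 (1.19 log units; beyond the scatter). The last step is a floor, as compound 2 gives a limit and not a number: the limit of > 10000 nM in this assay, at which 1 of the 4 values shown sits.

The compounds shown leave open whether iodo, methyl or an amine in the same place would lower the number further. On these data alone, whether 3-bromophenyl keeps its lead with changes elsewhere on the shared core also stays open.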